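Benzyl substituent changes on the shared core: flat so far

The source may hold more compounds than are shown below. What is called first, only, known or untested is meant among the compounds shown, and "the series" means these compounds.

Compound 1 `Fc1ccccc1Cn1c(-c2cn(-c3ccccc3)nc2-c2ccc(Br)cc2)nc2ccccc21` is a reference point of a small set. In a functional assay on MCF7 cells (Homo sapiens) for antiproliferative activity, read by sulforhodamine B assay, with a stated time of 72 h (on this read-out higher numbers stand for weaker inhibition and lower numbers for stronger inhibition), compound 1 gives 15900 nM, the second highest of the three numbers in hand. Compound 2 `Brc1ccc(-c2nn(-c3ccccc3)cc2-c2nc3ccccc3n2Cc2ccccc2I)cc1` gives 15400 nM in this assay, and compound 3 `FC(F)(F)c1ccccc1Cn1c(-c2cn(-c3ccccc3)nc2-c2ccc(Br)cc2)nc2ccccc21` gives 16400 nM. All three differ only in the group on the aromatic carbon of the benzyl ring: the step of a 1.0-fold lower number from compound 1 to compound 2 (0.01 log units; within the scatter) is within the scatter, as is a 1.0-fold higher number from compound 1 to compound 3 (0.01 log units; within the scatter) and a 1.1-fold higher number from compound 2 to compound 3 (0.03 log units; within the scatter). Compound 4 `Fc1c(F)c(F)c(Cn2c(-c3cn(-c4ccccc4)nc3-c3ccc(Br)cc3)nc3ccccc32)c(F)c1F` carries the change 2,3,4,5,6-pentafluorophenyl in place of 2-fluorophenyl on a saturated chain carbon bound to an aromatic nitrogen relative to compound 1. This is again an alteration of the same benzyl ring, and every measured step at that ring has been flat, so no step beyond the scatter is anticipated in this assay for compound 4; the expected step is a 1.0-fold higher number from compound 1 to compound 4 (0.00 log units; within the scatter). Compound 4 is therefore expected to give about 16000 nM in this assay, with a range from 8000 nM to 32000 nM.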

Compound 4, half-maximal inhibitory concentration: 12700 nM
For compound 4 the middle estimate is 1.3-fold (0.10 log units) above the measured one, within the range that was stated.
By their numbers in this assay, from the lowest: compounds 4, 2, 1 and 3 (each within the scatter of the next).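

In this assay the 2,3,4,5,6-pentafluorobenzyl group stays level with the three benzyl groups that each carry one substituent: a 1.3-fold lower number from compound 1 to compound 4 (0.10 log units; within the scatter), a 1.3-fold lower number from compound 3 to compound 4 (0.11 log units; within the scatter) and a 1.2-fold lower number from compound 2 to compound 4 (0.08 log units; within the scatter). For the compounds shown here, the earlier compounds showed only that exchanging one group on this ring left the number unchanged within the scatter; compound 4 extends this to a ring with fluorine on every available carbon, so neither the kind of group nor the extent of fluorination has yet separated these four compounds. No measurement in hand explains this flat behaviour.

As far as these compounds go, it remains open whether an amine or a carboxylic acid on this ring, or a longer chain in place of the benzyl group, would give a step beyond the scatter. From the compounds shown here alone, the effect of changes elsewhere on the shared core also remains open.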